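The compounds below may be only part of what the source reports. "The series", "measured", "known", "first", "only" and "open" are said of these compounds alone.

Compound 1 `Cc1cnc(N2CCC(c3coc4c(N5CCc6cc(S(C)(=O)=O)ccc65)ncnc34)CC2)nc1` gives 159% in a functional assay on cells for agonist activity at Glucose-dependent insulinotropic receptor (Homo sapiens), read by a luciferase reporter, with a stated time of 4 h; on this read-out lower numbers stand for smaller maximal responses and higher numbers for larger maximal responses. Compound 2 `CC(=O)c1cnc(N2CCC(c3coc4c(N5CCc6cc(S(C)(=O)=O)ccc65)ncnc34)CC2)nc1` gives 12%. Compound 3 `CC(O)c1cnc(N2CCC(c3coc4c(N5CCc6cc(S(C)(=O)=O)ccc65)ncnc34)CC2)nc1` gives 33%.

Compound 3 stands second highest of the three: it is a number 21 percentage points higher from compound 2 to compound 3 (beyond the scatter), and well short of compound 1, which is a number 126 percentage points lower from compound 1 to compound 3 (beyond the scatter). Compound 4 `CS(=O)(=O)c1ccc2c(c1)CCN2c1ncnc2c(C3CCN(c4ncc(Cl)cn4)CC3)coc12` carries chloro in place of 1-hydroxyethyl on an aromatic carbon. For the measured compounds named here, the steps that bear on this are a number 126 percentage points lower from compound 1 to compound 3 (beyond the scatter) and a number 147 percentage points lower from compound 1 to compound 2 (beyond the scatter), both large losses when a larger group replaced methyl; compound 3 retracing toward a one-atom substituent is therefore expected to recover much of that response, though chloro itself is untested here. The step is estimated as a number 82 percentage points higher from compound 3 to compound 4 (beyond the scatter), giving compound 4 an expected 115% (range 55% to 170%).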

Compound 4, largest response reached (Emax), in percent of the reference or control that the assay uses: 117%
Compound 4: the middle estimate sits 2 percentage points below what was measured; measured number inside the range.
By their numbers in this assay, from the lowest: compound 2; then compound 3; then compound 4; then compound 1.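

Chloro at this position restores much of the response in this assay, with a number 84 percentage points higher from compound 3 to compound 4 (beyond the scatter) and a number 105 percentage points higher from compound 2 to compound 4 (beyond the scatter), so the losses seen with 1-hydroxyethyl and acetyl do not extend to every replacement of methyl. Chloro still does not match methyl, with a number 42 percentage points lower from compound 1 to compound 4 (beyond the scatter), so the two are not interchangeable here. No available evidence explains these steps. On these data alone, whether fluoro, bromo or methoxy would come closer to methyl stays open. So does whether an amine or a nitrile at this position would keep the response or lose it as acetyl does.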